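Swapping a chloro for a methoxyethoxy ether

This account rests on a few compounds, and the source may have more. Where it says the series, first, only, none or still open, it means among the compounds named here.

Of the compounds shown here, two sharing one core have been measured in an ADME assay on liver (Homo sapiens) for metabolic stability, read by LC-MS, using microsomes, tested at 1 uM, in the presence of a further agent that is not named here; a lower number here means that the compound disappears faster, a higher number that the compound lasts longer. Compound 1 `COCCOc1ccc(N2C(=O)N(CC(=O)N/N=C/C=C/c3ccc(C)o3)C(C)(C)C2N(O)C(=O)Nc2ccc(Cl)cc2)cc1` gives 57.8 h in this assay. Among the measured compounds shown here, compound 2 `Cc1ccc(/C=C/C=N/NC(=O)CN2C(=O)N(c3ccc(Cl)cc3)C(N(O)C(=O)Nc3ccc(Cl)cc3)C2(C)C)o1` gives 16.5 h, the lower of the two numbers, and the only step on record, a 3.5-fold lower number from compound 1 to compound 2 (0.54 log units; beyond the scatter), runs from compound 1 to compound 2. Compound 3 `COCCOc1ccc(NC(=O)N(O)C2N(c3ccc(Cl)cc3)C(=O)N(CC(=O)N/N=C/C=C/c3ccc(C)o3)C2(C)C)cc1` is not yet measured. It differs from compound 2 by 2-methoxyethoxy in place of chloro on an aromatic carbon, so the same pair of groups is exchanged as in the measured step, but on the other aryl ring and in the opposite direction. That measured step is the only one that bears on the change, and it gives a modest rise for the ether over the chloro. The expectation for compound 3 is therefore a rise of about a 2.4-fold higher number from compound 2 to compound 3 (0.38 log units; beyond the scatter) in this assay, though the different position leaves the size uncertain. Compound 3 is estimated at 40 h, within 15 h to 100 h.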

Compound 3, half-life: 23.1 h
For compound 3 the middle estimate is 1.7-fold (0.24 log units) above the measured one; low and high end bracket the measured number.
By their numbers in this assay, from the lowest: compounds 2 and 3 (each within the scatter of the next); then compound 1.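

In this assay, 2-methoxyethoxy in place of chloro on the (4-chlorophenyl)amino group gives a 1.4-fold higher number from compound 2 to compound 3 (0.15 log units; within the scatter), so at this position the exchange leaves no readable difference. The same pair of groups exchanged on the other 4-chlorophenyl group gives a 3.5-fold lower number from compound 1 to compound 2 (0.54 log units; beyond the scatter), with chloro entering there, and that step lies beyond the scatter, so in these compounds the outcome of the exchange depends on which aryl ring carries it. Nothing measured here accounts for this difference between the two rings. Going by these compounds, it remains open whether another group at this position, such as methoxy, fluoro or a 2-(dimethylamino)ethoxy chain, would shift the half-life beyond the scatter. Also open, on these data alone, is what 2-methoxyethoxy on both aryl rings together would give.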